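Propargyl to methyl on two related cores

The source may report more compounds than this note shows. Statements on the series, on what has been measured and on what is new or still open speak of the compounds shown alone.

Measured compounds:
compound 1 `C#CCN(Cc1ccc2nc(C)nc(O)c2c1)c1cc(F)c(C(=O)N[C@@H](CCC(=O)O)C(=O)O)c(F)c1`, in a functional assay on L1210 cells (Mus musculus) for inhibition (on this read-out lower numbers stand for stronger inhibition and higher numbers for weaker inhibition), compound 1 gives 62 nM
compound 2 `Cc1nc(O)c2cc(CN(C)c3cc(F)c(C(=O)N[C@@H](CCC(=O)O)C(=O)O)c(F)c3)ccc2n1`, compound 2 gives 50 nM
compound 3 `C#CCN(Cc1ccc2nc(C)[nH]c(=O)c2c1)c1ccc(C(=O)N[C@@H](CCC(=O)O)C(=O)O)c(F)c1`, compound 3 gives 27 nM

Compound 2 differs from compound 1 by hydrogen in place of ethynyl on a saturated chain carbon bound to a nitrogen on an aromatic ring, and that change gave a 1.2-fold lower number from compound 1 to compound 2 (0.09 log units; within the scatter). Compound 4 `Cc1nc2ccc(CN(C)c3ccc(C(=O)N[C@@H](CCC(=O)O)C(=O)O)c(F)c3)cc2c(=O)[nH]1` differs from compound 3 by hydrogen in place of ethynyl on a saturated chain carbon bound to a nitrogen on an aromatic ring, the same change at the same place. The difference between the core of compound 1 and the core of compound 3 is not broken down here; compound 2 and compound 3 lie within the scatter of each other, while compound 1 stands beyond it from compound 3.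

For compound 4 a step of a 1.1-fold lower number from compound 3 to compound 4 (0.05 log units; within the scatter) in this assay is expected, small like the earlier one, because the same change gave a 1.2-fold lower number from compound 1 to compound 2 (0.09 log units; within the scatter). Compound 4 is therefore estimated at 24 nM, between 10 nM and 55 nM.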

Compound 4, half-maximal inhibitory concentration: 19 nM
For compound 4 the middle estimate is 1.3-fold (0.10 log units) above the measured one; measured number inside the range.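

In this assay, propargyl to methyl gives a 1.4-fold lower number from compound 3 to compound 4 (0.15 log units; within the scatter), and the step on the other core is of similar size: the same change on two cores in this assay, a 1.2-fold lower number (0.09 log units; within the scatter) from compound 1 to compound 2 and a 1.4-fold lower number (0.15 log units; within the scatter) from compound 3 to compound 4, 1.1-fold (0.06 log units) apart, within the scatter of two such steps. On these two cores, the change therefore carries over as a step within the scatter, and neither step reads as a real gain or loss. This does not show that the step would stay small on a further core, and the two pairs do not separate out what the difference between the cores contributes.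

Still open, from the compounds shown here alone, is how ethyl, a longer chain or a chain ending in an amine would read in this assay in place of propargyl. Also open, going by these compounds, is whether any such group would behave alike on both cores.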